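The compounds below may be only part of what the source reports. "The series", "measured", "known", "first", "only" and "open" are said of these compounds alone.

Working notes on the series. Compound 1 `N#Cc1cccc(COc2ccc(-c3cc(CN4CCN(Cc5ccc(C(F)(F)F)cc5)CC4)no3)cc2)c1` and compound 2 `N#Cc1cccc(COc2ccc(-c3cc(CN4CCN(c5ccc(C(F)(F)F)cn5)CC4)no3)cc2)c1` share one core and differ only in the group on the amine nitrogen in the ring. In a functional assay on MCF7 cells (Homo sapiens) for antiproliferative activity, read by sulforhodamine B assay, with a stated time of 72 h (a lower number here means a stronger inhibitor, a higher number a weaker inhibitor), compound 1 gives 800 nM. In this assay compound 2 gives 1400 nM. Among the measured compounds shown here, the single step measured so far, a 1.8-fold higher number from compound 1 to compound 2 (0.24 log units; within the scatter), lies within the scatter. Among the two numbers so far compound 2 carries the higher one, but its gap to compound 1 is within the scatter, so no order between the two is claimed.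

Compound 3 `N#Cc1cccc(COc2ccc(-c3cc(CN4CCN(c5ccc(F)cc5)CC4)no3)cc2)c1` has not yet been measured. It differs from compound 2 in one place: 4-fluorophenyl in place of 5-(trifluoromethyl)pyridin-2-yl on an amine nitrogen in a ring. For the measured compounds named here, the only measured step that bears on this position is a 1.8-fold higher number from compound 1 to compound 2 (0.24 log units; within the scatter), which exchanged the group on the same ring nitrogen without a change beyond the scatter. Going by the values given here, no measured step tests 4-fluorophenyl itself, so the data do not resolve its effect. For compound 3 no step beyond the scatter is therefore expected in this assay. The expected step is a 1.2-fold lower number from compound 2 to compound 3 (0.07 log units; within the scatter). Compound 3 is estimated at 1200 nM, with a range from 450 nM to 3200 nM.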

Compound 3, half-maximal inhibitory concentration: 2400 nM
Compound 3: middle estimate off by 2.0-fold (0.30 log units), on the low side; measured number inside the range.
By their numbers in this assay, from the lowest: compounds 1, 2 and 3 (each within the scatter of the next, the first and the last beyond it).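

On the ring nitrogen, 4-fluorophenyl in place of 5-(trifluoromethyl)pyridin-2-yl gives a 1.7-fold higher number from compound 2 to compound 3 (0.23 log units; within the scatter) in this assay, so no order between these two groups is claimed. The same position does register a change in the comparison with the benzyl group: 4-fluorophenyl in place of 4-(trifluoromethyl)benzyl gives a 3.0-fold higher number from compound 1 to compound 3 (0.48 log units; beyond the scatter), a modest step and the first at this nitrogen to pass the scatter, although compound 2 lies within the scatter of both compound 1 and compound 3, so the three groups do not fall into two separate levels. No measurement on hand explains this step.

The shown compounds do not separate the contribution of the benzyl carbon link from that of the ring substituent, and a 4-fluorobenzyl group on the same nitrogen would pair directly with compound 3 on that question. As far as these compounds go, it also remains open how this position responds to a group without an aromatic ring, such as cyclohexyl or a short chain ending in a carboxylic acid.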